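Trimethoxyphenyl in place of phenyl on the shared core

The source may hold more compounds than are shown below. What is called first, only, known or untested is meant among the compounds shown, and "the series" means these compounds.

Compound 1 `CCOC(=O)CN(Cc1ccccc1)c1nc(NCc2ccccc2)ncc1[N+](=O)[O-]` carries a benzyl group on the amine of the shared core. In a functional assay on A549 cells (Homo sapiens) for antiproliferative activity, read by MTT assay, with a stated time of 48 h (on this read-out lower numbers stand for stronger inhibition and higher numbers for weaker inhibition), compound 1 gives only a limit, > 100000 nM. Compound 2 `CCOC(=O)CN(Cc1ccccc1)c1nc(Nc2ccccc2)ncc1[N+](=O)[O-]` carries a phenyl group there instead. In this assay compound 2 likewise gives only a limit, > 100000 nM. The step that the two limits leave unreadable from compound 1 to compound 2 therefore cannot be sized, since (the limit of > 100000 nM in this assay, at which 2 of the 2 values shown sit).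

Compound 3 `CCOC(=O)CN(Cc1ccccc1)c1nc(Nc2cc(OC)c(OC)c(OC)c2)ncc1[N+](=O)[O-]` differs from compound 2 by 3,4,5-trimethoxyphenyl in place of phenyl on a nitrogen on an aromatic ring. For the measured compounds named here, no measured step with a readable size bears on this change, and both known values are limits, so there is no numerical footing for a direction. Compound 3 is expected to sit near the same limit, with an estimated step of an at least 1.2-fold lower number from compound 2 to compound 3 (0.09 log units; that floor lies within the scatter) of unreadable direction. Compound 3 is expected to give about 80000 nM in this assay, within a range of 5000 nM to 300000 nM, with a good chance that again only a limit is reported.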

Compound 3, half-maximal inhibitory concentration: > 100000 nM
Compound 3 ended at the assay's limit (the forecaster's own chance of this, stated with the estimate: 60%); at least 1.2-fold (0.09 log units) between middle value and limit.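

For the compounds shown here, no step among compound 1, compound 2 and compound 3 can be read in this assay, since each gives only a limit: the limit of > 100000 nM in this assay, at which 3 of the 3 values shown sit. The compounds shown leave open how far each lies from that limit, and whether benzyl, phenyl or 3,4,5-trimethoxyphenyl on that nitrogen makes any difference.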